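Compound 3 to compound 4: a methoxycarbonyl side chain

This account rests on a few compounds, and the source may have more. Where it says the series, first, only, none or still open, it means among the compounds named here.

In a functional assay on A-427 cells (Homo sapiens) for cytotoxicity, read by colorimetric assay and MTT assay (a higher number here means a weaker inhibitor, a lower number a stronger inhibitor), compound 3 (`COc1ccc(-c2cc3c(OC)cc(OC)cc3n(CCCC#N)c2=O)cc1`) gives 10000 nM and stands level with compound 1 (`CCN(CC)C(=O)Cn1c(=O)c(-c2ccc(OC)cc2)cc2c(OC)cc(OC)cc21`) at 10000 nM and compound 2 (`COc1ccc(-c2cc3c(OC)cc(OC)cc3n(CC#N)c2=O)cc1`) at 10000 nM in this small set. Compound 4 (`COC(=O)CCn1c(=O)c(-c2ccc(OC)cc2)cc2c(OC)cc(OC)cc21`) has methoxycarbonyl in place of cyanomethyl on a saturated chain carbon, two bonds along the chain from an aromatic nitrogen; methoxycarbonyl in place of cyanomethyl on a saturated chain carbon, two bonds along the chain from an aromatic nitrogen is the counted difference. Three earlier side-chain steps bear on this change: no change at the digits printed from compound 1 to compound 2 (within the scatter) and no change at the digits printed from compound 1 to compound 3 (within the scatter) and no change at the digits printed from compound 2 to compound 3 (within the scatter) make up the record so far. None of them moved the value, so no step beyond the scatter and no direction is expected here. The expected outcome in this assay is no change at the digits printed from compound 3 to compound 4 (within the scatter) for this change. Compound 4 is estimated at 10000 nM within an expected range of 5000 nM to 20000 nM for this series.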

Compound 4, half-maximal inhibitory concentration: 10000 nM
Estimate against measurement, compound 4: no gap at the digits printed; measured number inside the range.
By their numbers in this assay, from the lowest: compounds 1, 2, 3 and 4 (each within the scatter of the next).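

Methoxycarbonyl on a saturated chain carbon, two bonds along the chain from an aromatic nitrogen, leaves the value in this assay unmoved (no change at the digits printed from compound 3 to compound 4 (within the scatter)). The comparisons with the other side chains read the same (no change at the digits printed from compound 2 to compound 4 (within the scatter); no change at the digits printed from compound 1 to compound 4 (within the scatter)), so a methoxycarbonyl end does not separate from the nitrile or diethylcarbamoyl ends in these four compounds. No measurement on hand explains this flat record.

Going by these compounds, whether a carboxylic acid, an amine or a longer chain at this position would separate from these four remains open.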